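This account rests on a few compounds, and the source may have more. Where it says the series, first, only, none or still open, it means among the compounds named here.

Compound 1 `CC(C)(C)c1ccccc1Oc1ccc(-c2cccc(C(=O)O)c2)cc1NC(=O)Nc1ccccc1`: 1500 nM
Compound 2 `CCc1ccccc1Oc1ccc(-c2ccc(OC)c(C(=O)O)c2)cc1NC(=O)Nc1ccc(C)cc1`: 540 nM

Both were tested in an assay on HeLa cells for inhibition of Indoleamine 2,3-dioxygenase 1 (Homo sapiens), with a stated time of 20 h; a lower number here means a stronger inhibitor, a higher number a weaker inhibitor. Compound 2 gives the lower of the two numbers; compound 1 at 1500 nM lies beyond the usual scatter from it, but the two structures differ in several places, so no single step can be read from the pair. Compound 3 `COc1ccc(-c2ccc(Oc3ccccc3C(C)(C)CO)c(NC(=O)Nc3ccc(C)cc3)c2)cc1C(=O)O` is not yet measured. It differs from compound 2 by 1-(hydroxymethyl)-1-methylethyl in place of ethyl on an aromatic carbon. Among the measured compounds shown here, no measured pair here isolates this change. The expected step is a 1.1-fold lower number from compound 2 to compound 3 (0.03 log units; within the scatter), small and within the scatter in either direction. Compound 3 is estimated at 500 nM, with a range from 180 nM to 1400 nM.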

Compound 3, half-maximal inhibitory concentration: 2400 nM
Estimate against measurement, compound 3: 4.8-fold (0.68 log units) below, outside the stated range (above it).
By their numbers in this assay, from the lowest: compound 2; then compounds 1 and 3 (each within the scatter of the next).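

In this assay, among the compounds shown here, 1-(hydroxymethyl)-1-methylethyl in place of ethyl, on the aromatic carbon ortho to a large group, gives a 4.4-fold higher number from compound 2 to compound 3 (0.65 log units; beyond the scatter) and is the first single-place step. This position therefore responds to the change, and the response runs toward the weaker side. Nothing measured here accounts for the step.

The swap alters the chain and adds a hydroxyl in one move, so the share of each remains unresolved. As far as these compounds go, whether a 2-hydroxyethyl chain or an amine at this position would behave alike also stays open.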